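Replacing the tetrazolyl group of compound 3

This account rests on a few compounds, and the source may have more. Where it says the series, first, only, none or still open, it means among the compounds named here.

In an ADME assay on cells (Homo sapiens) for cytotoxicity (on this read-out lower numbers stand for higher toxicity in this test and higher numbers for lower toxicity in this test), compound 3 `CC(CCOc1ccc(-c2nnn(C)n2)cc1)CCN1CCN(c2ccncc2)C1=O` gives > 25000 nM, which is a limit and not a number. Compound 3 therefore stands at the limit of > 25000 nM in this assay, at which 2 of the 3 values shown sit. Compound 1 `CCc1nc(-c2ccc(OCCC(C)CCN3CCN(c4ccncc4)C3=O)cc2)no1` gives > 25000 nM, also a limit. Compound 2 `O=C1N(CCC(CCOc2ccc(-c3ccc(Cl)cc3)cc2)C(F)(F)F)CCN1c1ccncc1` gives > 12500 nM, again a limit. For the measured compounds named here, no compound measured so far has a true number to rank it.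

Compound 4 `CC(CCOc1ccc(-c2ccc(Cl)cc2)cc1)CCN1CCN(c2ccncc2)C1=O` carries 4-chlorophenyl in place of 2-methyl-2H-tetrazol-5-yl on an aromatic carbon. Going by the values given here, the one measured step at this place is a step that the two limits leave unreadable from compound 1 to compound 3, and it gives no size to carry over. The closest guide is compound 2, which also bears 4-chlorophenyl and still reaches only its limit of > 12500 nM.

A small move in this assay is therefore expected, if any, and it would lean towards lower numbers. The expected change is an at least 1.2-fold lower number from compound 3 to compound 4 (0.09 log units; that floor lies within the scatter). For compound 4 the estimate is 20000 nM. The expected range for compound 4 runs from 9000 nM to 40000 nM.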

Compound 4, half-maximal cytotoxic concentration: > 25000 nM
Compound 4: no number, only a limit; the forecaster's own chance of this, stated with the estimate: 70%; middle value at least 1.2-fold (0.09 log units) away from the limit.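

In this assay compound 4 gives > 25000 nM, which is a limit and not a number. All four values are limits, so the steps to compound 4 from compound 1, compound 2 and compound 3 cannot be read. The compounds shown leave open whether any of these group changes shifts the read-out at all.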